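A few compounds are considered here, and "the series" means these few. Any claim that something is new, unique, unknown or untested is made for them only; others in the source may bear on it.

Measured compounds:
compound 1 `Cc1ccccc1NC(=O)N1CCC(c2nc(-c3ccc4ccccc4n3)no2)CC1`, 440 nM
compound 2 `O=C(NC1CCCCC1)N1CCC(c2nc(-c3ccc4ccccc4n3)no2)CC1`, 57 nM
compound 3 `Cn1c(-c2noc(C3CCN(C(=O)NC4CCCCC4)CC3)n2)nc2ccccc21`, 89 nM

In a functional assay on Shh Light II cells (Mus musculus) for inhibition, read by a luciferase reporter (a higher number here means a weaker inhibitor, a lower number a stronger inhibitor), compound 2 gives the lowest number of the three. Compound 3 lies within the scatter of it, the step being a 1.6-fold higher number from compound 2 to compound 3 (0.19 log units; within the scatter), so the two cannot be ordered. Compound 1 stands clearly apart: the step of a 7.7-fold lower number from compound 1 to compound 2 (0.89 log units; beyond the scatter) shows that putting a saturated ring in place of an aromatic one on the urea nitrogen brought a modestly lower number.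

Compound 4 `O=C(N1CCC(c2nc(-c3ccc4ccccc4n3)no2)CC1)N1CCCc2ccccc21` has not been measured. It differs from compound 2 in one place: 1,2,3,4-tetrahydroquinolin-1-yl in place of cyclohexylamino on a carbonyl carbon. The entering group brings back an aromatic ring and, unlike the cyclohexylamino group it replaces, is fused and tied into the urea nitrogen, so the amide hydrogen is gone. Among the measured compounds shown here, the only step that bears on this is a 7.7-fold lower number from compound 1 to compound 2 (0.89 log units; beyond the scatter), which moved in the opposite sense when an aromatic group gave way to a saturated one. For the measured compounds named here, no measured pair tests the loss of the hydrogen-bond donor itself. A modestly higher number is therefore expected for compound 4, estimated as a 5.3-fold higher number from compound 2 to compound 4 (0.72 log units; beyond the scatter), giving 300 nM with a range from 80 nM to 1200 nM.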

Compound 4, half-maximal inhibitory concentration: 2300 nM
Beside the measured number, compound 4's estimate is 7.7-fold (0.88 log units) below it; measured number outside the range, above it.
By their numbers in this assay, from the lowest: compounds 2 and 3 (each within the scatter of the next); then compound 1; then compound 4.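

In this assay, this place on the carbonyl carbon proves far less forgiving than the earlier compounds suggested: bringing in 1,2,3,4-tetrahydroquinolin-1-yl gives a 40-fold higher number from compound 2 to compound 4 (1.61 log units; beyond the scatter), the largest step seen so far among these compounds. Having an aromatic ring there does not by itself account for the whole rise, since a step with an aromatic ring on both sides still gives a 5.2-fold higher number from compound 1 to compound 4 (0.72 log units; beyond the scatter). Both steps remove the amide hydrogen and tie the ring into the urea nitrogen at the same time, so the two changes cannot be told apart here, and no supporting data are available to explain the rise.

A piperidin-1-yl group or an N-methylcyclohexylamino group on the same carbonyl carbon would have no amide hydrogen and no aromatic ring, and so would show whether removing that hydrogen alone raises the number this far. From the compounds shown here alone, it also remains open whether a plain phenylamino group behaves like the (2-methylphenyl)amino group of compound 1, and whether 1-methyl-1H-benzimidazol-2-yl in place of quinolin-2-yl would leave the number of compound 4 unchanged.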